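Adding fluoro to the isopropoxycarbonyl compound 3

The compounds below may be only part of what the source reports. "The series", "measured", "known", "first", "only" and "open" are said of these compounds alone.

Measured in a functional assay on the whole organism for inhibition, with Scenedesmus acutus as the target; a lower number here means a stronger inhibitor, a higher number a weaker inhibitor:
- compound 1 `O=C1C2=C(CCCC2)C(=O)N1c1ccc(Cl)cc1F`: 37.2 nM
- compound 2 `O=C(O)c1cc(N2C(=O)C3=C(CCCC3)C2=O)c(F)cc1Cl`: 1000 nM
- compound 3 `CC(C)OC(=O)c1cc(N2C(=O)C3=C(CCCC3)C2=O)ccc1Cl`: 1230 nM

Compound 3 at 1230 nM lies within the scatter of compound 2 at 1000 nM, and both stand well above compound 1 at 37.2 nM. Compound 4 `CC(C)OC(=O)c1cc(N2C(=O)C3=C(CCCC3)C2=O)c(F)cc1Cl` is compound 3 with one change, fluoro in place of hydrogen on an aromatic carbon, ortho to a large group, meta to a chloro group and para to an isopropoxycarbonyl group.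

Among the compounds with values here, no measured step makes this change. The only one available is a 27-fold higher number from compound 1 to compound 2 (1.43 log units; beyond the scatter), for carboxy in place of hydrogen, a large step but a different change, and both of its compounds already carry the fluoro group. The indirect hint is that compound 1, a fluoro compound, reaches 37.2 nM, though it also lacks the isopropoxycarbonyl group. A moderate move to a lower number is therefore expected, with real uncertainty. The expected change is a 4.9-fold lower number from compound 3 to compound 4 (0.69 log units; beyond the scatter). For compound 4 the estimated value in this assay is 250 nM, with an expected range of 40 nM to 1200 nM.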

Compound 4, half-maximal inhibitory concentration: 13.8 nM
Compound 4: the middle estimate sits 18-fold (1.26 log units) above what was measured, and the stated range ends above it.
By their numbers in this assay, from the lowest: compound 4; then compound 1; then compounds 2 and 3 (each within the scatter of the next).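

In this assay, within the data shown here, fluoro in place of hydrogen at this position, ortho to a large group, gives an 89-fold lower number from compound 3 to compound 4 (1.95 log units; beyond the scatter) and so counts for far more than the earlier compounds could show. With that fluoro present, the isopropoxycarbonyl group is more than merely tolerated: isopropyl in place of the acid hydrogen gives a 72-fold lower number from compound 2 to compound 4 (1.86 log units; beyond the scatter) and the whole group set onto compound 1 gives a 2.7-fold lower number from compound 1 to compound 4 (0.43 log units; beyond the scatter) (a modest step, while the carboxy group on the same compound gave a 27-fold higher number from compound 1 to compound 2 (1.43 log units; beyond the scatter) in the other direction). Nothing given here accounts for the size of the fluoro step.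

The compounds shown leave open whether bromo or a methoxy group at this position would do the same as fluoro. They also leave open whether a shorter methyl ester or an amide could stand in for the isopropoxycarbonyl group.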